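The source may report more compounds than this note shows. Statements on the series, on what has been measured and on what is new or still open speak of the compounds shown alone.

Working notes on the series. Compound 1 `COc1ccc(C(=O)Nc2ccccc2F)cc1OC1CCCC1` gives 10700 nM in an assay on isolated protein for inhibition of phosphodiesterase 4A (Sus scrofa); a higher number here means a weaker inhibitor, a lower number a stronger inhibitor; compound 2 `COc1ccc(C(=O)Nc2ccccc2SC)cc1OC1CCCC1` gives 1200 nM; compound 3 `COc1ccc(C(=O)Nc2ncccc2C)cc1OC1CCCC1` gives 3100 nM, the second highest number of the three, with a 3.5-fold lower number from compound 1 to compound 3 (0.54 log units; beyond the scatter) and a 2.6-fold higher number from compound 2 to compound 3 (0.41 log units; beyond the scatter). Compound 4 `COc1ccc(C(=O)Nc2c(C)nsc2C#N)cc1OC1CCCC1` carries 5-cyano-3-methyl-1,2-thiazol-4-yl in place of 3-methylpyridin-2-yl on an amide-type nitrogen. Among the measured compounds shown here, the steps that bear on this are the two earlier exchanges of the group on the amide-type nitrogen, an 8.9-fold lower number from compound 1 to compound 2 (0.95 log units; beyond the scatter) and a 2.6-fold higher number from compound 2 to compound 3 (0.41 log units; beyond the scatter), both modest and in either direction. A step of similar size is therefore expected for compound 4, direction uncertain, so the estimate is a 1.2-fold lower number from compound 3 to compound 4 (0.09 log units; within the scatter). For compound 4 the expected value is 2500 nM, with a range from 500 nM to 10000 nM.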

Compound 4, half-maximal inhibitory concentration: 200 nM
Beside the measured number, compound 4's estimate is 13-fold (1.10 log units) above it; measured number outside the range, below it.
By their numbers in this assay, from the lowest: compound 4; then compound 2; then compound 3; then compound 1.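

In this assay, the exchange on the amide-type nitrogen reaches further than the earlier exchanges did, with 5-cyano-3-methyl-1,2-thiazol-4-yl giving a 16-fold lower number from compound 3 to compound 4 (1.19 log units; beyond the scatter) and a 6.0-fold lower number from compound 2 to compound 4 (0.78 log units; beyond the scatter) and a 54-fold lower number from compound 1 to compound 4 (1.73 log units; beyond the scatter). A five-membered aromatic ring with 2 hetero atoms is therefore tolerated at this place, and it gives the lowest number of the four compounds. Nothing available explains this step.

On these data alone, the ring and the cyano group enter together, so their separate shares remain open. Also open, as far as these compounds go, is how an amine or a carboxylic acid in place of the cyano group would read.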